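This account rests on a few compounds, and the source may have more. Where it says the series, first, only, none or still open, it means among the compounds named here.

Of the compounds shown here, three define the series so far: compound 1 `CN1CCN(c2nc(N)nc(COc3cccc(Cl)c3)n2)CC1`, compound 2 `Cc1ccc(C(C)C)c(OCc2nc(N)nc(N3CCN(C)CC3)n2)c1` and compound 3 `Cc1ccccc1OCc1nc(N)nc(N2CCN(C)CC2)n1`. In an assay on HEK293 cells for displacement of a labelled ligand from 5-hydroxytryptamine receptor 7 (Homo sapiens), read by radioligand binding, with a stated time of 1 h (on this read-out higher numbers stand for weaker inhibition and lower numbers for stronger inhibition), compound 1 gives 5820 nM, the second highest of the three numbers; compound 2 gives 12000 nM and compound 3 gives 514 nM. For the measured compounds named here, the only single change measured at the oxygen on a saturated carbon is an 11-fold lower number from compound 1 to compound 3 (1.05 log units; beyond the scatter). Compound 4 `Cc1ccc(OCc2nc(N)nc(N3CCN(C)CC3)n2)cc1` makes a related change: 4-methylphenyl in place of 3-chlorophenyl on an oxygen on a saturated carbon. Since a methyl-bearing phenyl once helped a great deal, yet compound 2 with its own methyl-bearing phenyl sits at 12000 nM, compound 4 is expected to improve only moderately, a 2.9-fold lower number from compound 1 to compound 4 (0.46 log units; beyond the scatter). Compound 4 is therefore estimated at 2000 nM, within 500 nM to 8000 nM.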

Compound 4, inhibition constant: 16100 nM
For compound 4 the middle estimate is 8.1-fold (0.91 log units) below the measured one, and the stated range ends below it.
By their numbers in this assay, from the lowest: compound 3; then compound 1; then compounds 2 and 4 (each within the scatter of the next).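

The 4-methylphenyl group does not repeat the gain of 2-methylphenyl on this oxygen on a saturated carbon: in this assay the change runs the other way (a 2.8-fold higher number from compound 1 to compound 4 (0.44 log units; beyond the scatter)), against the drop seen before (an 11-fold lower number from compound 1 to compound 3 (1.05 log units; beyond the scatter)). The two methylphenyl groups themselves lie far apart (a 31-fold higher number from compound 3 to compound 4 (1.50 log units; beyond the scatter)), so a methyl-bearing phenyl does not by itself help here; which of the two is present decides the result. Nothing measured here accounts for this difference. Still open, from the compounds shown here alone, is whether 2-chlorophenyl or 2-methoxyphenyl would behave like 2-methylphenyl on this oxygen.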